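Carboxy for trifluoromethyl on the shared core

A few compounds are considered here, and "the series" means these few. Any claim that something is new, unique, unknown or untested is made for them only; others in the source may bear on it.

Of the compounds shown here, three with the shared core have been measured in an assay on isolated protein for inhibition of 2-Hydroxyacid oxidase 2 (Homo sapiens), tested at 1 uM; on this read-out higher numbers stand for a stronger effect at the one concentration tested and lower numbers for a weaker effect. Compound 1 `Cc1n[nH]c(C(=O)O)c1Cc1ccc2ccccc2n1` gives 2%. Compound 2 `Cc1n[nH]c(C(=O)O)c1Cc1ccc(C(F)(F)F)cc1` gives 9%. Compound 3 `Cc1n[nH]c(C(=O)O)c1Cc1ccccc1Oc1ccccc1` gives 9%. Compound 2 stands level with compound 3 at the digits shown, and its distance to compound 1 lies within the usual scatter, so the three numbers do not separate from one another. For the measured compounds named here, no pair of measured compounds differs in only one place, so no measured step exists to lean on. Compound 4 `Cc1n[nH]c(C(=O)O)c1Cc1ccc(C(=O)O)cc1` differs from compound 2 in one place: carboxy in place of trifluoromethyl on an aromatic carbon. With all three measured numbers low and close together, the expected step of a number 1 percentage points lower from compound 2 to compound 4 (within the scatter) is small, in no sure direction, and not beyond the scatter. Compound 4 is therefore estimated at 8%, between 0% and 22%.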

Compound 4, a percentage reported as inhibition, at one concentration (the size of the read-out at that concentration, not a potency): 3%
For compound 4 the middle estimate is 5 percentage points above the measured one; low and high end bracket the measured number.
By their numbers in this assay, from the lowest: compounds 1, 4, 2 and 3 (each within the scatter of the next).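

For the compounds shown here, the only one-place step so far, measured in this assay, is a number 6 percentage points lower from compound 2 to compound 4 (within the scatter) for carboxy in place of trifluoromethyl on an aromatic carbon para to a large group. At this position, the exchange therefore leaves the read-out at the single tested concentration unresolved from the scatter, and neither group is separated from the other. No measured evidence bears on this result.

On these data alone, whether any group at this position can lift the read-out beyond the scatter remains open. An amine, a nitrile or a primary amide there would test this.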